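Sulfonyl vinyl pyridines: chloro added beside ring nitrogen

The compounds below may be only part of what the source reports. "The series", "measured", "known", "first", "only" and "open" are said of these compounds alone.

Measured so far:
compound 1, `O=S(=O)(/C=C/c1cccc(Cl)n1)c1ccc(F)cc1`, 2790 nM
compound 2, `O=S(=O)(/C=C/c1ccccn1)c1ccc(Cl)cc1`, 1730 nM

Both compounds were read in an assay on U2OS cells for activation of nuclear factor erythroid 2-related factor 2 (Homo sapiens), read by beta-arrestin recruitment, with a stated time of 6 h; a lower number here means that less compound is needed, a higher number that more compound is needed for the effect. Compound 2 holds the lowest of the two numbers; its nearest neighbour is compound 1, whose number is higher, but the gap between the two lies within the scatter, so no order between them can be stated. Among the measured compounds shown here, compounds 1 and 2 differ in two places at once, so their pair gives no isolated step.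

Compound 3, `O=S(=O)(/C=C/c1cccc(Cl)n1)c1ccc(Cl)cc1`, is not yet measured in this assay. Relative to compound 2 the change is chloro in place of hydrogen on an aromatic carbon. For the measured compounds named here, no single-point step with this change is available among the measured pair; the only hint is that compound 1, which also carries chloro on the six-membered aromatic ring with 1 nitrogen, sits within the scatter of compound 2. The expected step of a 1.2-fold higher number from compound 2 to compound 3 (0.08 log units; within the scatter) is therefore small and not beyond the scatter, in either direction. Compound 3 is expected to give 2100 nM in this assay, within a range of 900 nM to 4800 nM.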

Compound 3, half-maximal effective concentration: 1460 nM
Compound 3: the middle estimate sits 1.4-fold (0.16 log units) above what was measured; the range from low to high includes it.
By their numbers in this assay, from the lowest: compounds 3, 2 and 1 (each within the scatter of the next).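

In this assay, chloro in place of hydrogen on an aromatic carbon, next to the ring nitrogen, now has a reading in one place: a 1.2-fold lower number from compound 2 to compound 3 (0.07 log units; within the scatter). At this position in the series, the hydrogen and the chloro therefore cannot be told apart by the number. With the chloro next to the ring nitrogen kept, chloro in place of fluoro on an aromatic carbon gives a 1.9-fold lower number from compound 1 to compound 3 (0.28 log units; within the scatter), so that second change also stays inside the noise of the assay, and no measurement is available that could account for either step.

The compounds shown carry only hydrogen or chloro at this position and only fluoro or chloro at the other varied place, so it remains open whether an amine, a carboxylic acid, a methoxy group or a longer chain there would move the number beyond the scatter. Also open, from the compounds shown here alone, is whether chloro in place of hydrogen next to the ring nitrogen would give a similar step with fluoro, rather than chloro, at the other varied place.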